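This account rests on a few compounds, and the source may have more. Where it says the series, first, only, none or still open, it means among the compounds named here.

The measured compounds:
compound 1, `CCN(CC)CN1C(=O)/C(=N\c2nc3ccc(C)cc3s2)c2ccccc21`, giving 63500 nM in a functional assay on MDA-MB-468 cells (Homo sapiens) for cytotoxicity, read by sulforhodamine B assay, with a stated time of 48 h; a lower number here means a stronger inhibitor of growth, a higher number a weaker inhibitor of growth
compound 2, `CCN(CC)CN1C(=O)/C(=N\c2nc3ccc(C)cc3s2)c2c(Br)cccc21`, giving 43100 nM
compound 3, `CCN(CC)CN1C(=O)C(=O)c2c(Br)cccc21`, giving 11700 nM

Compound 1 stands at the highest of the three numbers in this assay; compound 2 is nearest to it, compound 3 furthest, at a lower number beyond the scatter. The only change among these three that touches a single place is a 1.5-fold lower number from compound 1 to compound 2 (0.17 log units; within the scatter), a step within the scatter. Among the compounds with values here, compound 2 and compound 3 differ in more than one place, so their two values show only that compound 3 sits lower.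

The unmeasured compound 4, `Cc1ccc2nc(/N=C3\C(=O)N(CN(C)C)c4ccccc43)sc2c1`, differs from compound 1 by dimethylamino in place of diethylamino on a saturated chain carbon bound to an amide-type nitrogen in a ring. Within the data shown here, no measured step touches this part of the molecule: the one single-place step known concerns the bromo substituent on an aromatic carbon and lies within the scatter, and nothing among the measured compounds varies the amine on the chain. These data therefore give no ground for expecting a step beyond the scatter in this assay in either direction. Compound 4 is accordingly expected to give about 60000 nM, with a range from 25000 nM to 150000 nM. For compound 4 this estimate means a step of a 1.1-fold lower number from compound 1 to compound 4 (0.02 log units; within the scatter), expected to stay within the scatter.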

Compound 4, concentration for 50% growth inhibition: 35500 nM
Beside the measured number, compound 4's estimate is 1.7-fold (0.23 log units) above it, within the range that was stated.
By their numbers in this assay, from the lowest: compound 3; then compounds 4, 2 and 1 (each within the scatter of the next).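

In this assay, the amine on the chain now has its first measured single-place step, and it reads a 1.8-fold lower number from compound 1 to compound 4 (0.25 log units; within the scatter). Within the data shown here, the earlier compounds left this part of the molecule untouched, and the only single-place step among them concerned the bromo substituent on an aromatic carbon. For this pair, going from diethylamino with 5 heavy atoms to dimethylamino with 3, on a saturated chain carbon bound to an amide-type nitrogen in a ring, leaves the number within the scatter, with the hydrogen-bond donor and acceptor counts the same on both sides, and no measurement shown here bears on why the step stays this small.

What the compounds shown leave open is whether a cyclic amine such as piperidine or morpholine, or a longer chain carrying the amine, would give a step beyond the scatter from compound 1. Also open, as far as these compounds go, is whether dimethylamino in place of diethylamino gives a similar step on the bromo-substituted core of compound 2, since a single pair on the unsubstituted core cannot settle that.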